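A few compounds are considered here, and "the series" means these few. Any claim that something is new, unique, unknown or untested is made for them only; others in the source may bear on it.

Going by the values given here, in a functional assay on LOX IMVI cells (Homo sapiens) for cytotoxicity (on this read-out lower numbers stand for stronger inhibition of growth and higher numbers for weaker inhibition of growth), three related compounds have numbers so far. Compound 1 (`OCCCCC#Cc1ccccc1C#Cc1ccccn1`) gives 27700 nM, compound 2 (`OCCCCC#Cc1ccccc1C#Cc1ccccc1C(F)(F)F`) gives 4900 nM, and compound 3 (`COc1cccc(C#Cc2ccccc2C#CCCCCO)c1`) gives 6300 nM. Compound 3 thus stands level with compound 2, within the usual scatter, while compound 1 has a higher number, beyond that scatter. Compound 4 (`OCCCCC#Cc1ccccc1C#Cc1cccc(C(F)(F)F)c1`) carries trifluoromethyl in place of methoxy on an aromatic carbon, meta to a large group (trifluoromethyl in place of methoxy on an aromatic carbon). Among the compounds with values here, no measured pair shows this swap directly, but compound 2 also carries trifluoromethyl and reaches 4900 nM. In this assay, no change beyond the scatter is therefore expected, with an estimated step of a 1.1-fold lower number from compound 3 to compound 4 (0.06 log units; within the scatter). For compound 4 the estimated value is 5500 nM, with an expected range from 2500 nM to 12000 nM.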

Compound 4, concentration for 50% growth inhibition: 17500 nM
Estimate against measurement, compound 4: 3.2-fold (0.50 log units) below, and the stated range ends below it.
By their numbers in this assay, from the lowest: compounds 2 and 3 (each within the scatter of the next); then compounds 4 and 1 (each within the scatter of the next).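

In this assay, putting trifluoromethyl in place of methoxy on an aromatic carbon, meta to a large group, gives a 2.8-fold higher number from compound 3 to compound 4 (0.44 log units; beyond the scatter), a modest loss of growth inhibition. Going by these compounds alone, the earlier compounds held no pair differing in one place, so this is the first direct reading of a single change on the shared core. No measurement is available that explains this step. One pair cannot show whether losing methoxy or gaining trifluoromethyl matters more. As far as these compounds go, how an amine or a carboxylic acid would behave at this position also remains open.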